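From Methyl to Fluoro: Little Change Expected

This account rests on a few compounds, and the source may have more. Where it says the series, first, only, none or still open, it means among the compounds named here.

Of the compounds shown here, three sharing one core have been measured. Compound 1 `Nc1nc(N)c2cc(CSC(=S)N3CCN(C4CCCCC4)CC3)ccc2n1` carries a cyclohexyl on an amine nitrogen in a ring, and in a functional assay on HT-29 cells (Homo sapiens) for antiproliferative activity, read by MTT assay, with a stated time of 72 h (on this read-out lower numbers stand for stronger inhibition and higher numbers for weaker inhibition), compound 1 gives 4050 nM. Compound 2 `Cc1ccccc1N1CCN(C(=S)SCc2ccc3nc(N)nc(N)c3c2)CC1` puts 2-methylphenyl there; in this assay compound 2 gives 2950 nM, the lowest number shown, though the step of a 1.4-fold lower number from compound 1 to compound 2 (0.14 log units; within the scatter) lies within the scatter. Compound 3 `Cc1ccc(N2CCN(C(=S)SCc3ccc4nc(N)nc(N)c4c3)CC2)c(C)c1` with 2,4-dimethylphenyl gives 2970 nM in this assay; the steps of a 1.4-fold lower number from compound 1 to compound 3 (0.13 log units; within the scatter) and a 1.0-fold higher number from compound 2 to compound 3 (0.00 log units; within the scatter) are likewise within the scatter. Compound 4 `Nc1nc(N)c2cc(CSC(=S)N3CCN(c4ccccc4F)CC3)ccc2n1` differs from compound 2 by fluoro in place of methyl on an aromatic carbon. With every measured change at this end of the molecule staying within the scatter, no step beyond it is expected. For compound 4 the estimate is 3000 nM, ranging from 1500 nM to 6000 nM. The expected step is a 1.0-fold higher number from compound 2 to compound 4 (0.01 log units; within the scatter).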

Compound 4, half-maximal inhibitory concentration: 5420 nM
Compound 4: middle estimate off by 1.8-fold (0.26 log units), on the low side; low and high end bracket the measured number.
By their numbers in this assay, from the lowest: compounds 2, 3, 1 and 4 (each within the scatter of the next).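

Fluoro in place of methyl shows that a non-carbon atom at this spot on the aromatic ring also leaves this assay within the scatter, with a 1.8-fold higher number from compound 2 to compound 4 (0.26 log units; within the scatter) as the step. The 2-fluorophenyl group likewise cannot be told apart from the other groups on this amine nitrogen, given a 1.8-fold higher number from compound 3 to compound 4 (0.26 log units; within the scatter) and a 1.3-fold higher number from compound 1 to compound 4 (0.13 log units; within the scatter) within the scatter. No measurement at hand explains these small differences.

Still open, from the compounds shown here alone, is whether an amine or a carboxylic acid on this aromatic ring would move the number beyond the scatter. The same question holds for a longer chain in place of the ring.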